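Notes on the aryl group of the amide chain

A few compounds are considered here, and "the series" means these few. Any claim that something is new, unique, unknown or untested is made for them only; others in the source may bear on it.

Measured in a functional assay on MDA-MB-231 cells (Homo sapiens) for inhibition, read by MTT assay, with a stated time of 48 h; a lower number here means a stronger inhibitor, a higher number a weaker inhibitor:
compound 1 `COc1cc(/C=C/c2ccc(NC(=O)/C=C/c3ccc(C(F)(F)F)cc3)cc2)cc(OC)c1`: 3520 nM
compound 2 `COc1cc(/C=C/c2ccc(NC(=O)/C=C/c3ccccc3F)cc2)cc(OC)c1`: 2380 nM
compound 3 `COc1cc(/C=C/c2ccc(NC(=O)/C=C/c3ccc(Cl)cc3)cc2)cc(OC)c1`: 14100 nM

Compound 3 gives the highest number of the three: a 4.0-fold higher number from compound 1 to compound 3 (0.60 log units; beyond the scatter) and a 5.9-fold higher number from compound 2 to compound 3 (0.77 log units; beyond the scatter), both beyond the scatter, while a 1.5-fold lower number from compound 1 to compound 2 (0.17 log units; within the scatter) stays within it. Compound 4 `COc1cc(/C=C/c2ccc(NC(=O)/C=C/c3ccc(O)c(O)c3)cc2)cc(OC)c1` differs from compound 3 by 3,4-dihydroxyphenyl in place of 4-chlorophenyl on a double-bonded chain carbon bound to a double-bonded chain carbon. Among the measured compounds shown here, no measured step introduces hydroxyl-bearing aryl groups; the steps seen only exchange halogenated aryl groups, and those moved the number by modest amounts. For compound 4 the step of a 2.8-fold lower number from compound 3 to compound 4 (0.45 log units; beyond the scatter) is expected with little confidence in either direction, and a size no larger than the halogen exchanges is the working expectation. The estimate for compound 4 in this assay is 5000 nM, within 1500 nM to 20000 nM.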

Compound 4, half-maximal inhibitory concentration: 4230 nM
Beside the measured number, compound 4's estimate is 1.2-fold (0.07 log units) above it; low and high end bracket the measured number.
By their numbers in this assay, from the lowest: compounds 2, 1 and 4 (each within the scatter of the next); then compound 3.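

In this assay, 3,4-dihydroxyphenyl brings hydrogen-bond donors to this position, which no earlier aryl group carried, with a 3.3-fold lower number from compound 3 to compound 4 (0.52 log units; beyond the scatter) separating it from 4-chlorophenyl. With a 1.8-fold higher number from compound 2 to compound 4 (0.25 log units; within the scatter) and a 1.2-fold higher number from compound 1 to compound 4 (0.08 log units; within the scatter) it sits within the scatter of the 2-fluorophenyl and 4-(trifluoromethyl)phenyl groups, so among these compounds only compound 3 stands apart. No available evidence bears on this result.

Still open is whether both hydroxyl groups are needed, since a single hydroxyl on this aryl group is not among the compounds shown. Going by these compounds, how an amine or a carboxylic acid on this ring would read also remains open.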